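The source may hold more compounds than are shown below. What is called first, only, known or untested is meant among the compounds shown, and "the series" means these compounds.

Of the compounds shown here, three of one shared core have been measured in a functional assay on MDA-MB-231 cells (Homo sapiens) for inhibition, read by sulforhodamine B assay, tested at 10 uM; on this read-out higher numbers stand for more inhibition at the one concentration tested (going by the name of the read-out) and lower numbers for less inhibition. Compound 1, `CN1CCN(c2ccc(C3=NN(C(=O)/C=C/c4ccccc4)C(c4ccc(N(C)C)cc4)C3)cc2)CC1`, gives 35.9%. Compound 2, `CN(C)c1ccc(C2CC(c3ccc(-n4cncn4)cc3)=NN2C(=O)CCCl)cc1`, gives 3.7%. Compound 3, `CN(C)c1ccc(C2CC(c3ccc(-n4cncn4)cc3)=NN2C(=O)c2ccc(C(F)(F)F)cc2)cc1`, gives 16.7%, which places compound 3 second of the three numbers: compound 2 lies closest, beyond the scatter below it, and compound 1 lies furthest, beyond the scatter above it. Compound 4, `CN(C)c1ccc(C2CC(c3ccc(-n4cncn4)cc3)=NN2C(=O)/C=C/c2ccccc2)cc1`, is not yet measured. It differs from compound 3 in one place: 2-phenylethenyl in place of 4-(trifluoromethyl)phenyl on a carbonyl carbon. The group that leaves is 4-(trifluoromethyl)phenyl; the group that enters is 2-phenylethenyl, with one double bond outside aromatic rings; both sit on a carbonyl carbon whose other neighbour is an amide-type nitrogen in a ring.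

Within the data shown here, one measured step bears on this position on the carbonyl: a number 13 percentage points higher from compound 2 to compound 3 (beyond the scatter). Compound 1 also carries 2-phenylethenyl on its carbonyl, though on a different core, and its value in this assay stands above that of compound 3. A further rise is therefore expected, a number 10.3 percentage points higher from compound 3 to compound 4 (beyond the scatter). Compound 4 is expected to give 27%, with a range from 8% to 46%.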

Compound 4, a percentage reported as inhibition, at one concentration (the size of the read-out at that concentration, not a potency): 8.5%
Compound 4: the middle estimate sits 18.5 percentage points above what was measured; low and high end bracket the measured number.
By their numbers in this assay, from the lowest: compounds 2, 4 and 3 (each within the scatter of the next, the first and the last beyond it); then compound 1.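

In this assay, 2-phenylethenyl on the carbonyl carbon does not stand apart from the other two groups tried there on the shared core: replacing 4-(trifluoromethyl)phenyl gives a number 8.2 percentage points lower from compound 3 to compound 4 (within the scatter), and replacing 2-chloroethyl gives a number 4.8 percentage points higher from compound 2 to compound 4 (within the scatter). The 2-phenylethenyl group alone therefore does not bring a high number, since with that group held constant, 1H-1,2,4-triazol-1-yl in place of 4-methylpiperazin-1-yl on an aromatic carbon goes with a number 27.4 percentage points lower from compound 1 to compound 4 (beyond the scatter). Nothing measured here offers an explanation for these numbers.

As far as these compounds go, whether 4-methylpiperazin-1-yl would give a similar change with 4-(trifluoromethyl)phenyl or 2-chloroethyl on the carbonyl carbon remains open. So does the outcome with another amine, such as morpholine, on the aromatic carbon, or with a longer carbon chain on the carbonyl carbon.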